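Triazolylthioacetanilides: methoxy deletion and paw edema inhibition

The source may report more compounds than this note shows. Statements on the series, on what has been measured and on what is new or still open speak of the compounds shown alone.

Measured compounds:
compound 1 `COc1ccc(-c2nnc(SCC(=O)Nc3ccc(/C(C)=N/O)cc3)n2-c2ccccc2)cc1` gives 58% in a functional assay on the whole organism (strain albino) for inhibition, with Rattus norvegicus as the target, read by paw edema, with stated times of 30 min and 5 h, at a dose of 0.28 mmol/kg by the oral route; on this read-out higher numbers stand for more inhibition at the one dose given (going by the name of the read-out) and lower numbers for less inhibition
compound 2 `CCn1c(SCC(=O)Nc2ccc(C(C)=O)cc2)nnc1-c1ccc(OC)c(OC)c1` gives 66% in this assay
compound 3 `COc1ccc(-c2nnc(SCC(=O)Nc3ccc(/C(C)=N/O)cc3)n2-c2ccccc2)cc1OC` gives 76% in this assay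

Compound 3 and compound 1 differ by hydrogen in place of methoxy on an aromatic carbon and the step of a number 18 percentage points lower from compound 3 to compound 1 (beyond the scatter) is beyond the scatter. Compound 2 and compound 3 share the same pattern of two methoxy groups, but the difference between their two cores is not broken down here. Compound 2 and compound 1 lie within the scatter of each other.

Among the compounds with values here, compound 4 `CCn1c(SCC(=O)Nc2ccc(C(C)=O)cc2)nnc1-c1ccc(OC)cc1` is not yet measured; it differs from compound 2 by hydrogen in place of methoxy on an aromatic carbon, the same change in the same place as the one from compound 3 to compound 1. Within the data shown here, for compound 4 a drop of a number 17 percentage points lower from compound 2 to compound 4 (beyond the scatter) is expected in this assay, resting on the single earlier step of a number 18 percentage points lower from compound 3 to compound 1 (beyond the scatter) seen with compound 3 and compound 1. Compound 4 is thus estimated at 49%, between 36% and 62%.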

Compound 4, a percentage reported as inhibition, in the whole organism at one dose (the size of the read-out at that dose, not a potency): 62%
Compound 4: the middle estimate sits 13 percentage points below what was measured; low and high end bracket the measured number.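

Going from 3,4-dimethoxyphenyl to 4-methoxyphenyl on the core of compound 2 gives, in this assay, a number 4 percentage points lower from compound 2 to compound 4 (within the scatter) and is thus not a step that can be told from repeat scatter. Set side by side, the steps on the two cores cannot be told apart: the same change on two cores in this assay, a number 18 percentage points lower (beyond the scatter) from compound 3 to compound 1 and a number 4 percentage points lower (within the scatter) from compound 2 to compound 4, 14 percentage points apart, within the scatter of two such steps

Two pairs show neither that the change carries a fixed size from one core to the other nor that its size depends on the core, so the step seen on one core gives only a loose guide to the other.

Open, from the compounds shown here alone, is how the read-out responds when a hydroxy group or an amine stands in place of the methoxy. Also open, going by these compounds, is what a longer chain in place of the ethyl on the core of compound 2 would give.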